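This account rests on a few compounds, and the source may have more. Where it says the series, first, only, none or still open, it means among the compounds named here.

Compound 1 `Nc1cc(N)c2nc(-c3ccccc3)c(Oc3ccc(Cl)c(Cl)c3)nc2c1`: 85100 nM
Compound 2 `CCOC(=O)[C@H](CCC(=O)O)NC(=O)c1ccc(CNc2nc3cc(N)cc(N)c3nc2-c2ccccc2)cc1`: < 100000 nM
Compound 3 `CCOC(=O)[C@H](CCC(=O)O)NC(=O)c1ccc(Oc2nc3cc(N)cc(N)c3nc2-c2ccccc2)cc1`: < 100000 nM

In a functional assay on HOP-62 cells (Homo sapiens) for inhibition, read by sulforhodamine B assay, with a stated time of 48 h (on this read-out higher numbers stand for lower toxicity in this test and lower numbers for higher toxicity in this test), compound 1 gives 85100 nM. Compound 2 returns only a limit in this assay, < 100000 nM. Compound 3 likewise returns only a limit, < 100000 nM. Within the data shown here, compound 1 therefore carries the only measured number among the three, while the other two sit at the limit (the limit of < 100000 nM in this assay, at which 2 of the 3 values shown sit), so no ordering among them can be drawn from these figures.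

Compound 4 `Nc1cc(N)c2nc(-c3ccccc3)c(Sc3ccc(Cl)c(Cl)c3)nc2c1` has not yet been tested in this assay. It differs from compound 1 in one place: (3,4-dichlorophenyl)sulfanyl in place of 3,4-dichlorophenoxy on an aromatic carbon. Among the measured compounds shown here, no pair of measured compounds differs in a single place, so no measured step sets a scale for this swap. The exchange leaves the ring and the two chlorines untouched and replaces only the linking atom, and a step in this assay no larger than the usual scatter is expected, in either direction. Compound 4 is estimated at 70000 nM, with a range from 35000 nM to 140000 nM, which corresponds to an expected step of a 1.2-fold lower number from compound 1 to compound 4 (0.08 log units; within the scatter) that stays within the scatter.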

Compound 4, concentration lethal to 50% of the cells: < 100000 nM
Compound 4: only a limit was reported (the forecaster's own chance of this, stated with the estimate: 30%); the middle value does not contradict the limit.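

Compound 4 returns only a limit in this assay, < 100000 nM. The step from compound 1 to compound 4 therefore cannot be read. The compounds shown leave open whether (3,4-dichlorophenyl)sulfanyl in place of 3,4-dichlorophenoxy changes this read-out, and in which direction and by how much.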